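Swapping the bromo-fluoro ring back to methoxyphenyl

The source may hold more compounds than are shown below. What is called first, only, known or untested is meant among the compounds shown, and "the series" means these compounds.

Measured compounds:
- compound 1, `COc1ccccc1/C=c1/[nH]c(=O)/c(=C\c2ccccc2OC)n(C)c1=O`: 2200 nM
- compound 2, `C=CCn1c(=O)/c(=C\c2cc(Br)ccc2F)[nH]c(=O)/c1=C\c1ccccc1OC`: 5100 nM

In a functional assay on K562 cells (Homo sapiens) for cytotoxicity, read by CCK-8 assay, with a stated time of 72 h (a higher number here means a weaker inhibitor, a lower number a stronger inhibitor), compound 1 gives 2200 nM and compound 2 gives 5100 nM. Compound 2 stands at the higher of the two numbers, and its gap to compound 1 lies beyond the usual scatter. Compound 3 `C=CCn1c(=O)/c(=C\c2ccccc2OC)[nH]c(=O)/c1=C\c1ccccc1OC` differs from compound 2 by 2-methoxyphenyl in place of 5-bromo-2-fluorophenyl on a double-bonded chain carbon bound to an aromatic carbon. Within the data shown here, no measured pair shows this change on its own. Because compound 1, which carries 2-methoxyphenyl twice, gives 2200 nM, a modest downward step is expected, estimated as a 2.0-fold lower number from compound 2 to compound 3 (0.31 log units; beyond the scatter). For compound 3 the estimate in this assay is 2500 nM, with a range from 1000 nM to 6500 nM.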

Compound 3, half-maximal inhibitory concentration: 7400 nM
Compound 3: the middle estimate sits 3.0-fold (0.47 log units) below what was measured; the whole stated range lies below it.
By their numbers in this assay, from the lowest: compound 1; then compounds 2 and 3 (each within the scatter of the next).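

In this assay, 2-methoxyphenyl in place of 5-bromo-2-fluorophenyl on this double-bonded chain carbon gives a 1.5-fold higher number from compound 2 to compound 3 (0.16 log units; within the scatter) and so does not separate the two rings. Vinyl in place of hydrogen on a saturated chain carbon bound to an aromatic nitrogen gives a 3.4-fold higher number from compound 1 to compound 3 (0.53 log units; beyond the scatter) with 2-methoxyphenyl on both sides, so this chain change alone separates that pair. Nothing measured here explains either result.

From the compounds shown here alone, whether an amine or a carboxylic acid on the aromatic ring would shift the number remains open. So does the effect of a longer chain in place of vinyl.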